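The compounds below may be only part of what the source reports. "The series", "measured", "known", "first", "only" and "open" are said of these compounds alone.

Three compounds share a core in which a pyrrolidine bearing an acetic acid side chain sits on a phenyl ring that carries an oxygen-linked aromatic group. Compound 1 `Cc1ccccc1COc1ccc(N2CCC[C@H]2CC(=O)O)cc1` gives 190 nM in a functional assay on cells for agonist activity at Free fatty acid receptor 1 (Homo sapiens), read by FLIPR and calcium flux, with a stated time of 100 s; on this read-out lower numbers stand for an effect already at smaller amounts and higher numbers for an effect only at larger amounts of compound. Compound 2 `Cc1ccc(Oc2ccc(N3CCC[C@H]3CC(=O)O)cc2)cc1` gives 490 nM in this assay. Compound 3 `O=C(O)C[C@@H]1CCCN1c1ccc(Oc2ccc(Cl)cc2)cc1` gives 290 nM in this assay, which places it second highest of the three, its nearest neighbour being compound 1 and its furthest compound 2, with both gaps within the scatter.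

Compound 4 `COc1ccc(Oc2ccc(N3CCC[C@H]3CC(=O)O)cc2)cc1` differs from compound 3 by methoxy in place of chloro on an aromatic carbon, on an aromatic carbon of a six-membered aromatic ring of carbon only, para to a large group. For the measured compounds named here, the only measured step that touches this position is a 1.7-fold lower number from compound 2 to compound 3 (0.23 log units; within the scatter), a change in the same place that stayed within the scatter. The wider swaps, a 2.6-fold higher number from compound 1 to compound 2 (0.41 log units; beyond the scatter) and a 1.5-fold higher number from compound 1 to compound 3 (0.18 log units; within the scatter), were modest or within the scatter as well. A step of no more than modest size is therefore expected from compound 3 to compound 4, a 1.4-fold higher number from compound 3 to compound 4 (0.14 log units; within the scatter), and compound 4 is estimated at 400 nM, within 150 nM to 1200 nM.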

Compound 4, half-maximal effective concentration: 520 nM
Compound 4: middle estimate off by 1.3-fold (0.11 log units), on the low side; the measured number falls inside the stated range.
By their numbers in this assay, from the lowest: compounds 1, 3, 2 and 4 (each within the scatter of the next, the first and the last beyond it).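

For the compounds shown here, at this position, on an aromatic carbon para to a large group, methoxy is the only one of the three groups counted as a hydrogen-bond acceptor, yet replacing chloro gives a 1.8-fold higher number from compound 3 to compound 4 (0.25 log units; within the scatter) and replacing methyl gives a 1.1-fold higher number from compound 2 to compound 4 (0.03 log units; within the scatter) in this assay. With the earlier step between methyl and chloro, this puts all three groups within the scatter of one another. The larger swap gives a 2.7-fold higher number from compound 1 to compound 4 (0.44 log units; beyond the scatter) when 4-methoxyphenyl replaces 2-methylbenzyl, a modest step, but nothing at hand explains these results.

Still open, as far as these compounds go, is whether a different kind of group here, such as an amine, a carboxylic acid or a longer chain, would move the number further. Also open, from the compounds shown here alone, is whether methoxy would act alike on the aromatic ring of the 2-methylbenzyl group in compound 1.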